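This account rests on a few compounds, and the source may have more. Where it says the series, first, only, none or still open, it means among the compounds named here.

Compound 1 `CC1(C)Cc2c(OCc3ccccc3)ccc(C(=O)/C=C/c3ccc(F)cc3)c2O1` gives only the limit > 100000 nM in a functional assay on B16 cells (Mus musculus) for antiproliferative activity, read by MTT assay, with a stated time of 48 h; a lower number here means a stronger inhibitor, a higher number a weaker inhibitor.
Compound 2 `CC1(C)Cc2c(ccc(C(=O)/C=C/c3ccccc3)c2OCc2ccccc2)O1` likewise gives only the limit > 100000 nM in this assay.
Compound 3 `CC1(C)Cc2c(OCc3ccccc3)ccc(C(=O)/C=C/c3cn(-c4ccccc4)nc3-c3ccccc3)c2O1` also gives only the limit > 100000 nM in this assay.

Compound 2 therefore stands at the limit of > 100000 nM in this assay, at which 3 of the 3 values shown sit, and nothing separates it from the other two. Compound 4 `COc1ccc(/C=C/C(=O)c2ccc3c(c2OCc2ccccc2)CC(C)(C)O3)cc1` differs from compound 2 by methoxy in place of hydrogen on an aromatic carbon. For the measured compounds named here, no measured step of this kind is known here, so its size cannot be read from the data. Because compound 2 rests at the limit of > 100000 nM in this assay, at which 3 of the 3 values shown sit, the step of a number no higher from compound 2 to compound 4 (the limit leaves the size open) is expected to be none beyond the scatter, with no direction. Compound 4 is accordingly expected to give about 100000 nM, within 30000 nM to 300000 nM, most likely again only as a limit.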

Compound 4, half-maximal inhibitory concentration: > 100000 nM
Compound 4 ended at the assay's limit; the forecaster's own chance of this, stated with the estimate: 80%; the middle value sits exactly at the limit.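

For the compounds shown here, compound 2 and compound 4 both give only a limit in this assay, so no step between them can be read. The compounds shown leave open whether methoxy in place of hydrogen has any effect, and which change to the shared core would give a readable value: the limit of > 100000 nM in this assay, at which 4 of the 4 values shown sit.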